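Moving the Methyl Along the Chain of Compound 2

The source may report more compounds than this note shows. Statements on the series, on what has been measured and on what is new or still open speak of the compounds shown alone.

Among the three measured compounds, compound 2 `CNCCCc1c[nH]c2ccc(F)cc12` stands at the low end of the numbers in an assay on urine for inhibition of Myeloperoxidase (Homo sapiens) (a higher number here means a weaker inhibitor, a lower number a stronger inhibitor), where compound 2 gives 200 nM. Compound 3 `CN1CCN(CCCc2c[nH]c3ccc(F)cc23)CC1` gives 350 nM in this assay, a gap within the scatter, so nothing separates the two. For the measured compounds named here, compound 1 `NCc1c[nH]c2ccc(F)cc12` gives 900 nM in this assay, and the single step in this set, a 4.5-fold lower number from compound 1 to compound 2 (0.65 log units; beyond the scatter), is the only one that bears on the change now in view. Compound 4 `NCCCCc1c[nH]c2ccc(F)cc12` is built from the same atoms as compound 2, joined differently: aminomethyl in place of methylamino on a saturated chain carbon, three bonds along the chain from an aromatic carbon. In effect 3-(methylamino)propyl becomes 4-aminobutyl, the methyl moving from the nitrogen into the chain. The step from compound 1 to compound 2 changed chain length and the substitution on the nitrogen together, so it cannot separate the two, and its modest size sets the scale of what amine changes have done here. The numbers of compound 2 and compound 3 show that a different amine at the end of the same chain can stay within the scatter. Compound 4 is therefore expected to sit close to compound 2, with the estimated step of a 1.5-fold higher number from compound 2 to compound 4 (0.18 log units; within the scatter) not clearly beyond the scatter. Compound 4 is estimated at 300 nM, with a range from 120 nM to 800 nM.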

Compound 4, half-maximal inhibitory concentration: 15 nM
Compound 4: middle estimate off by 20-fold (1.30 log units), on the high side; the measured number lies below the stated range.
By their numbers in this assay, from the lowest: compound 4; then compounds 2 and 3 (each within the scatter of the next); then compound 1.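

Moving the methyl from the nitrogen into the chain, with no atom gained or lost, gives a 13-fold lower number from compound 2 to compound 4 (1.12 log units; beyond the scatter) in this assay, so at this position the arrangement of the same atoms matters far more than the earlier compounds suggested. Until now, changes at the amine end had given only a modest step or a gap within the scatter, whereas 4-aminobutyl now stands apart from 3-(methylamino)propyl, and the whole series spans a 60-fold lower number from compound 1 to compound 4 (1.78 log units; beyond the scatter), a large step that replaces amino with 3-aminopropyl on the saturated chain carbon bound to an aromatic carbon. No measurement shown here accounts for the size of this change.

The exchange of 3-(methylamino)propyl for 4-aminobutyl lengthens the chain and removes the methyl from the nitrogen at once, so the compounds shown cannot say how much of the step belongs to each. The shared core carrying 4-(methylamino)butyl or a plain 3-aminopropyl group would bear on that question, and a longer chain such as 5-aminopentyl would bear on whether the trend continues beyond compound 4.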